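Moving the Fluorine on the Benzyl Ring: Compound 3 to 4

A few compounds are considered here, and "the series" means these few. Any claim that something is new, unique, unknown or untested is made for them only; others in the source may bear on it.

The measured compounds in a functional assay on HT-29 cells (Homo sapiens) for inhibition, read by MTT assay, with a stated time of 48 h; on this read-out higher numbers stand for weaker inhibition and lower numbers for stronger inhibition:
- compound 1, `Cc1ccc(NC(=O)NC(=O)c2ccc(OCc3cccc(Cl)c3)cc2)cc1-c1nc2ccccc2[nH]1`, gives 15400 nM
- compound 2, `Cc1ccc(NC(=O)NC(=O)c2ccc(OCc3cccc(C(F)(F)F)c3)cc2)cc1-c1nc2ccccc2[nH]1`, gives 3520 nM
- compound 3, `Cc1ccc(NC(=O)NC(=O)c2ccc(OCc3ccccc3F)cc2)cc1-c1nc2ccccc2[nH]1`, gives 760 nM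

Compound 3 holds the lowest number of the three. Its nearest neighbour is compound 2, with a step of a 4.6-fold lower number from compound 2 to compound 3 (0.67 log units; beyond the scatter), and the widest gap is to compound 1, with a 20-fold lower number from compound 1 to compound 3 (1.31 log units; beyond the scatter). The change from compound 1 to compound 2 is a 4.4-fold lower number from compound 1 to compound 2 (0.64 log units; beyond the scatter).

Compound 4, `Cc1ccc(NC(=O)NC(=O)c2ccc(OCc3cccc(F)c3)cc2)cc1-c1nc2ccccc2[nH]1`, differs from compound 3 by 3-fluorophenyl in place of 2-fluorophenyl on a saturated chain carbon bound to an oxygen on an aromatic ring. Among the compounds with values here, no measured step moves a fluorine between positions; the two steps that reach compound 3 replace a 3-chlorophenyl or a 3-(trifluoromethyl)phenyl with the 2-fluorophenyl, and both lowered the number by modest to large amounts. Compound 4 carries its fluorine at the same ring position as those weaker groups, so a higher number than compound 3 is expected, though the size is uncertain. The expected step is a 2.6-fold higher number from compound 3 to compound 4 (0.42 log units; beyond the scatter), giving compound 4 an estimated 2000 nM, between 500 nM and 8000 nM.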

Compound 4, half-maximal inhibitory concentration: 38200 nM
Beside the measured number, compound 4's estimate is 19-fold (1.28 log units) below it; measured number above the stated range.
By their numbers in this assay, from the lowest: compound 3; then compound 2; then compound 1; then compound 4.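

In this assay, the place of the fluorine alone carries a large change: compounds with the same atoms, joined differently, go from 2-fluorobenzyl to 3-fluorobenzyl with (a 50-fold higher number from compound 3 to compound 4 (1.70 log units; beyond the scatter)). Among the three groups on the 3-substituted benzyl rings, fluoro does not improve on the heavier groups, since fluoro in place of trifluoromethyl gives (an 11-fold higher number from compound 2 to compound 4 (1.04 log units; beyond the scatter)) and fluoro in place of chloro gives (a 2.5-fold higher number from compound 1 to compound 4 (0.39 log units; beyond the scatter)). The low number of compound 3 therefore belongs to the 2-fluorobenzyl group and not to the presence of fluorine as such.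

Nothing available explains why the position of the fluorine matters so much.
Also open, from the compounds shown here alone, is how a methoxy group, an amine or a nitrile on the benzyl ring would compare with fluoro.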